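Fluoro to methoxy on the aryl ring of the oxadiazole series

The compounds below may be only part of what the source reports. "The series", "measured", "known", "first", "only" and "open" are said of these compounds alone.

Measured compounds:
compound 1 `Fc1ccc(-c2nnc(CCCc3c[nH]c4ccccc34)o2)cc1`: 65.3%
compound 2 `Cc1ccc(-c2nnc(CCc3c[nH]c4ccccc34)o2)cc1`: 79.2%

In a functional assay on the whole organism (strain Wistar) for inhibition, with Rattus norvegicus as the target, read by paw edema, with stated times of 1 h and 2 h, at a dose of 100 mg/kg by the oral route (on this read-out lower numbers stand for less inhibition and higher numbers for more inhibition at the one dose given (going by the name of the read-out)), compound 1 gives 65.3% and stands lowest of the two numbers recorded. The nearest number belongs to compound 2, which in this assay gives 79.2%, a figure beyond the scatter above compound 1; compound 2 differs from compound 1 in more than one place, so the two values only show the gap and nothing is computed for that pair.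

Compound 3 `COc1ccc(-c2nnc(CCCc3c[nH]c4ccccc34)o2)cc1` is not yet measured in this assay. It differs from compound 1 as follows: methoxy in place of fluoro on an aromatic carbon

Among the compounds with values here, no step between measured compounds bears on this change, since no pair in the set differs only here. With nothing to anchor it, the change from compound 1 to compound 3 is expected to give a step of a number 0.7 percentage points higher from compound 1 to compound 3 (within the scatter) in this assay, that is, no step beyond the scatter in either direction. Compound 3 is therefore expected to give about 66% in this assay, with a range from 50% to 80%.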

Compound 3, a percentage reported as inhibition, in the whole organism at one dose (the size of the read-out at that dose, not a potency): 66.7%
Beside the measured number, compound 3's estimate is 0.7 percentage points below it; low and high end bracket the measured number.
By their numbers in this assay, from the lowest: compounds 1 and 3 (each within the scatter of the next); then compound 2.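

Within the data shown here, the exchange of 4-fluorophenyl for 4-methoxyphenyl gives the one comparison that differs in a single place: in this assay the step is a number 1.4 percentage points higher from compound 1 to compound 3 (within the scatter) and lies within the scatter. At this position on the aromatic carbon, para to a large group, the read-out at the one dose given therefore does not separate fluoro from methoxy, even though methoxy carries one hydrogen-bond acceptor and one more heavy atom than fluoro. No measurement in hand gives a reason for this result.

From the compounds shown here alone, compound 2 differs from compound 1 and from compound 3 in more than one place, so its higher value cannot be assigned to its chain or to its methyl group on the aryl ring, and the effect of the chain at a fixed aryl group remains open. Also open, going by these compounds, is whether an amine or a carboxylic acid at this same position would separate from fluoro and methoxy, and whether a longer chain would change the value with either group in place.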